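The compounds below may be only part of what the source reports. "The series", "measured", "known", "first", "only" and "open" are said of these compounds alone.

Measured in a functional assay (B cells) with Mus musculus as the target (on this read-out lower numbers stand for an effect already at smaller amounts and higher numbers for an effect only at larger amounts of compound), so far
Compound 1 `CCCn1c(=O)n(C2OC(COP(=O)(O)O)[C@@H](O)[C@H]2O)c2nc(N)nc(O)c21` gives 15 uM
Compound 2 `CN(C)CCCn1c(=O)n(C2OC(CO)[C@@H](O)[C@H]2O)c2nc(N)nc(O)c21` gives 194 uM
Compound 3 `C=CCn1c(=S)n(C2OC(COC(C)=O)[C@H]3OC(C)(C)O[C@@H]23)c2nc(N)nc(O)c21` gives 50 uM

Compound 2 has the highest number of the three, and the numbers of both other compounds lie below it beyond the scatter. Compound 4 `CCCCn1c(=O)n(C2OC(CO)[C@@H](O)[C@H]2O)c2nc(N)nc(O)c21` has not yet been measured. It differs from compound 2 by methyl in place of dimethylamino on a saturated chain carbon, three bonds along the chain from an aromatic nitrogen with methyl in place of dimethylamino on a saturated chain carbon, three bonds along the chain from an aromatic nitrogen, so that 3-(dimethylamino)propyl becomes butyl.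

Going by the values given here, no two measured compounds differ in one place only, so the data give no direct size for such a step. Compound 1 at 15 uM and compound 3 at 50 uM both lack the dimethylamino group, though they also differ from compound 4 elsewhere. A move to a lower number, beyond the scatter, is therefore expected, and the estimated change is a 4.9-fold lower number from compound 2 to compound 4 (0.69 log units; beyond the scatter) in this assay with a wide margin. For compound 4 the expected value is 40 uM within an estimated range from 12 uM to 130 uM pending measurement.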

Compound 4, concentration for half-maximal effect: 11 uM
Estimate against measurement, compound 4: 3.6-fold (0.56 log units) above; the whole stated range lies above it.
By their numbers in this assay, from the lowest: compounds 4 and 1 (each within the scatter of the next); then compound 3; then compound 2.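

In this assay the exchange of 3-(dimethylamino)propyl for butyl gives an 18-fold lower number from compound 2 to compound 4 (1.25 log units; beyond the scatter) and so provides the first size for a single change among these compounds. It shows that this position, on a saturated chain carbon, three bonds along the chain from an aromatic nitrogen, responds strongly when methyl takes the place of dimethylamino and the rest of the compound stays the same. Nothing available here accounts for the size of this step.

The compounds shown leave open whether a longer chain, a primary amine or a carboxylic acid at this place would keep the number of compound 4 or move it. They also leave open whether the same exchange would give a step of like size on the core of compound 1 or of compound 3.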